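The compounds below may be only part of what the source reports. "The series", "measured", "known", "first", "only" and "open" are said of these compounds alone.

Compound 2 `CC1=C(/C=C/C(=O)/C=C/c2ccc(C)cc2)C(C)(C)CCC1` and compound 1 `CC1=C(/C=C/C(=O)/C=C/c2ccc(Br)cc2)C(C)(C)CCC1` share the same core and differ only in the group carried on the aromatic ring. In a functional assay on PC-3 cells (Homo sapiens) for cytotoxicity, read by sulforhodamine B assay, with a stated time of 48 h (a higher number here means a weaker inhibitor, a lower number a stronger inhibitor), compound 1 gives 18900 nM, and in this assay compound 2 gives 21500 nM. Among the two numbers known so far, compound 2 stands at the higher end, but the only step known, a 1.1-fold higher number from compound 1 to compound 2 (0.06 log units; within the scatter), lies within the scatter, so the two compounds cannot be told apart on these data.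

Compound 3 `CC1=C(/C=C/C(=O)/C=C/c2ccccc2Cl)C(C)(C)CCC1` is not yet measured in this assay. It differs from compound 2 by 2-chlorophenyl in place of 4-methylphenyl on a double-bonded chain carbon bound to a double-bonded chain carbon. Among the measured compounds shown here, the single measured step, a 1.1-fold higher number from compound 1 to compound 2 (0.06 log units; within the scatter), also exchanges one group on the aromatic ring for another and produced no change beyond the scatter; no measured pair involves a 2-chlorophenyl, so the evidence that bears on this change is thin. On that basis compound 3 is expected to show a step of a 1.1-fold lower number from compound 2 to compound 3 (0.03 log units; within the scatter), that is, no change beyond the scatter. Compound 3 is therefore estimated at 20000 nM in this assay, with a range from 8000 nM to 50000 nM.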

Compound 3, half-maximal inhibitory concentration: 11300 nM
For compound 3 the middle estimate is 1.8-fold (0.25 log units) above the measured one; measured number inside the range.
By their numbers in this assay, from the lowest: compounds 3, 1 and 2 (each within the scatter of the next).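

In this assay, 2-chlorophenyl in place of 4-methylphenyl on a double-bonded chain carbon bound to a double-bonded chain carbon gives a 1.9-fold lower number from compound 2 to compound 3 (0.28 log units; within the scatter), and 2-chlorophenyl in place of 4-bromophenyl at the same place gives a 1.7-fold lower number from compound 1 to compound 3 (0.22 log units; within the scatter). This place has now carried three different substituted phenyl groups, including one whose name carries a different ring number, and each step among them stays within the scatter, so compounds 1, 2 and 3 cannot be told apart on these data. Nothing available offers an explanation for these numbers.

All three groups leave open whether any change at this place can move the number beyond the scatter, since each is a phenyl ring carrying a single halogen or methyl group. Going by these compounds, an amine or a carboxylic acid on the aromatic ring, or a longer chain in place of the methyl group of compound 2, might show whether this place responds at all, and the shared core remains untested by these three compounds.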